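This account rests on a few compounds, and the source may have more. Where it says the series, first, only, none or still open, it means among the compounds named here.

Working notes on the series in a functional assay on A-431 cells (Homo sapiens) for antiproliferative activity, read by MTT assay, with a stated time of 72 h; on this read-out lower numbers stand for stronger inhibition and higher numbers for weaker inhibition. For the measured compounds named here, compound 1 (`CN1CCN(c2ccc(Nc3ncc4nc(Nc5ccc(F)cc5)n(-c5cccc(NC(=O)CO)c5)c4n3)cc2)CC1`) gives 1670 nM, the only number so far. Compound 2 (`CN1CCN(c2ccc(Nc3ncc4nc(Nc5ccc(F)cc5)n([C@@H]5CCCN(C(=O)CO)C5)c4n3)cc2)CC1`) stands at "not determined" (no result reported). Compound 3 (`CN1CCN(c2ccc(Nc3ncc4nc(Nc5ccc(F)cc5)n([C@@H]5CCN(C(=O)OC(C)(C)C)C5)c4n3)cc2)CC1`) stands at "not determined" (no result reported), so it has no single number and no rank in the series. The move to compound 4 (`CN1CCN(c2ccc(Nc3ncc4nc(Nc5ccc(F)cc5)n([C@H]5CCN(S(=O)(=O)C6CC6)C5)c4n3)cc2)CC1`) is 1-(cyclopropylsulfonyl)pyrrolidin-3-yl in place of 1-(tert-butoxycarbonyl)pyrrolidin-3-yl on an aromatic nitrogen. Going by the values given here, no measured step exists to size this change. In this assay no shift beyond the scatter is expected, in either direction, from the sole anchor, compound 1 at 1670 nM. For compound 4 the estimated value is 1500 nM, with an expected range of 400 nM to 6000 nM.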

Compound 4, half-maximal inhibitory concentration: 1670 nM
Compound 4: middle estimate off by 1.1-fold (0.05 log units), on the low side; measured number inside the range.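

In this assay the position on the aromatic nitrogen gives its first readable step: no change at the digits printed from compound 1 to compound 4 (within the scatter), with 1-(cyclopropylsulfonyl)pyrrolidin-3-yl in place of 3-(((hydroxymethyl)carbonyl)amino)phenyl. A phenyl group and a sulfonylated pyrrolidine at this place therefore sit within the scatter of each other on this read-out, and steps involving compound 2 or compound 3 cannot be read. Nothing available explains this result.

Open, on these data alone, is whether a free secondary amine on the pyrrolidine, or a carboxylic acid in place of the cyclopropyl group, would move the value beyond the scatter.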